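Truncation of the side chain: working notes

The source may report more compounds than this note shows. Statements on the series, on what has been measured and on what is new or still open speak of the compounds shown alone.

Measured so far:
compound 1, `C=C1CC[C@H]2C(C)(C)CCC[C@]2(C)[C@H]1C/C=C1\CC(OC)OC1=O`: 59.9%
compound 2, `C=C1CC[C@H]2C(C)(C)CCC[C@]2(C)[C@H]1C/C=C1\C=COC1=O`: 61.5%

In a functional assay on RAW264.7 cells (Mus musculus) for inhibition, read by ELISA, with stated times of 1 h and 18 h, tested at 20 uM (a higher number here means a weaker effect of the compound at the concentration tested, a lower number a stronger effect), compound 1 gives 59.9%. In this assay compound 2 gives 61.5%; this is the higher of the two numbers, but the gap to compound 1 lies within the scatter, so the two compounds read as equal here. Within the data shown here, no step between measured compounds is therefore available.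

Compound 3, `C=C1CC[C@H]2C(C)(C)CCC[C@]2(C)[C@H]1CC=O`, has not been measured in this assay. It differs from compound 2 as follows: a group of 2 heavy atoms (1 carbon, 1 oxygen; no ring) in place of a group of 7 heavy atoms (5 carbon, 2 oxygen; one five-membered non-aromatic ring with 1 hetero atom), on a saturated chain carbon bound to a saturated ring carbon. The change removes most of the side chain that compound 1 and compound 2 share. Since compound 2 gives 61.5% in this assay, the step from compound 2 to compound 3 is expected to be beyond the scatter and toward a weaker effect, that is, a higher number, a number 16.5 percentage points higher from compound 2 to compound 3 (beyond the scatter). In this assay compound 3 is estimated to give 78%, with a range from 58% to 96%.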

Compound 3, a percentage reported as activity, at one concentration (the size of the read-out at that concentration, not a potency): 72.8%
Compound 3: the middle estimate sits 5.2 percentage points above what was measured, within the range that was stated.
By their numbers in this assay, from the lowest: compounds 1 and 2 (each within the scatter of the next); then compound 3.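

In this assay, replacing the group of 7 heavy atoms with its five-membered ring by formyl, on a saturated chain carbon bound to a saturated ring carbon, gives a number 11.3 percentage points higher from compound 2 to compound 3 (beyond the scatter). This shows that the effect at this position depends on what the shared core carries, which compound 1 and compound 2 could not show, since they read as equal. No measurement on hand accounts for the step.

The change removes the ring and most of the side chain at once, so the compounds shown do not separate the contribution of the ring from that of the chain. Going by these compounds, it also remains open whether an amine, a carboxylic acid or a longer chain without a ring at this place would restore the effect seen with compound 2.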